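Triazole for Hydroxyl on the Cyclohexyl Ring

The source may hold more compounds than are shown below. What is called first, only, known or untested is meant among the compounds shown, and "the series" means these compounds.

Compound 1 `N#Cc1cnc(NCc2cnccc2C(F)(F)F)cc1N[C@H]1CC[C@@H](O)CC1` gives 100 nM in an assay on isolated protein for inhibition of protein kinase C theta type (Homo sapiens), read by TR-FRET, with a stated time of 2 h (a lower number here means a stronger inhibitor, a higher number a weaker inhibitor), the lowest of the three numbers measured. Its mirror image, compound 2 `N#Cc1cnc(NCc2cnccc2C(F)(F)F)cc1N[C@H]1CC[C@H](O)CC1`, gives 350 nM, and the step of a 3.5-fold higher number from compound 1 to compound 2 (0.54 log units; beyond the scatter) rests on (the fact that compounds 1 and 2 differ only in the configuration as drawn). Compound 3 `N#Cc1cnc(NCc2cnccc2C(F)(F)F)cc1NCC1CCOCC1`, which carries (oxan-4-yl)methyl in place of 4-hydroxycyclohexyl, gives 400 nM; the step of a 4.0-fold higher number from compound 1 to compound 3 (0.60 log units; beyond the scatter), while a 1.1-fold higher number from compound 2 to compound 3 (0.06 log units; within the scatter).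

Compound 4 `N#Cc1cnc(NCc2cnccc2C(F)(F)F)cc1N[C@H]1CC[C@@H](c2nc[nH]n2)CC1` keeps the configuration of compound 1 and differs from it in one place: 1H-1,2,4-triazol-3-yl in place of hydroxy on a saturated ring carbon. The step from compound 1 to compound 3, in which the hydroxy-bearing ring is exchanged, bears on this change most directly and was a modest loss; the step from compound 1 to compound 2 shows that the arrangement kept in compound 4 is the better one. Since the triazolyl group retains both a donor and acceptors where the hydroxy group stood, the step of a 1.5-fold higher number from compound 1 to compound 4 (0.18 log units; within the scatter) is expected to be small, at most a modest loss. Compound 4 is therefore estimated at 150 nM, within a range from 30 nM to 800 nM.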

Compound 4, half-maximal inhibitory concentration: 34 nM
The estimate for compound 4 lay 4.4-fold (0.64 log units) above the measured number; low and high end bracket the measured number.
By their numbers in this assay, from the lowest: compound 4; then compound 1; then compounds 2 and 3 (each within the scatter of the next).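

The saturated ring carbon accepts a five-membered aromatic ring with 3 hetero atoms in place of a single oxygen, and the change brings a gain rather than a loss: in this assay, 1H-1,2,4-triazol-3-yl in place of hydroxy gives a 2.9-fold lower number from compound 1 to compound 4 (0.47 log units; beyond the scatter). The two earlier changes from compound 1, inverting the configuration and exchanging the whole hydroxy-bearing substituent, both raised the number, so this is the first step shown that lowers it, and hydroxy is thus not the best group shown at this position. Nothing shown here establishes why the exchange lowers the number.

From the compounds shown here alone, whether the triazolyl group would give a similar step in the configuration of compound 2 remains open. Also open, going by these compounds, is how a carboxylic acid, an amine or a plain phenyl ring would fare on this same ring carbon, which would show whether the ring nitrogens of the triazole matter.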